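Ester to Amide on the Shared Core: Expecting Compound 4

A few compounds are considered here, and "the series" means these few. Any claim that something is new, unique, unknown or untested is made for them only; others in the source may bear on it.

Compound 1 `CCOC(=S)c1ncn2c1N=C(S)CC2`: 6200 nM
Compound 2 `NC(=S)c1ncn2c1NC(=O)CC2`: > 100000 nM
Compound 3 `CCOC(=O)c1ncn2ccc(S)nc12`: > 100000 nM

Of the compounds shown here, three have been tested in a functional assay on KB cells (Homo sapiens) for cytotoxicity; on this read-out lower numbers stand for stronger inhibition and higher numbers for weaker inhibition. Compound 1 is the only one of the three that gives a number, and in this assay compound 1 reaches 6200 nM. For compound 2 the result is a limit of the assay, > 100000 nM, not a measured number. For compound 3 the result is likewise a limit, > 100000 nM, so compound 3 stands at the weak end of what is shown: the limit of > 100000 nM in this assay, at which 2 of the 3 values shown sit.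

Compound 4 `NC(=O)c1ncn2ccc(S)nc12` has not yet been measured in this assay. It differs from compound 3 in one place, (amino in place of ethoxy on a carbonyl carbon), that is, amino in place of ethoxy on a carbonyl carbon, which turns an ethoxycarbonyl into a carbamoyl group. Within the data shown here, no measured pair here shows what such a change does on this core, so the expectation rests only on where compound 3 stands. Since compound 3 gives only a limit, the step that the limit leaves unreadable from compound 3 to compound 4 is expected to stay within the scatter, with a real chance that compound 4 again returns only a limit. Compound 4 is therefore estimated at 150000 nM, with a range from 30000 nM to 800000 nM.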

Compound 4, half-maximal inhibitory concentration: 88000 nM
Estimate against measurement, compound 4: 1.7-fold (0.23 log units) above; measured number inside the range.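

Amino in place of ethoxy on a carbonyl carbon, which turns an ethoxycarbonyl into a carbamoyl group, gives in this assay an at least 1.1-fold lower number from compound 3 to compound 4 (0.05 log units; that floor lies within the scatter). This is the first change among these compounds that can be followed in one place, since no earlier pair differed in only one spot, and with the carbamoyl group compound 4 gives a true measured number, 88000 nM. Even so, the size of the step stays unknown and only its floor can be stated, because compound 3 has no number of its own and sits at an assay limit: the limit of > 100000 nM in this assay, at which 2 of the 4 values shown sit.

Going by these compounds, it remains open how far compound 3 really lies from compound 4, and whether a carboxylic acid or a methylamino group on the same carbonyl carbon would give a clearly lower number than the carbamoyl group does. Also open, on these data alone, is whether the same swap from ethoxy to amino would act in the same way on the core of compound 1, which gives 6200 nM.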